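The source may hold more compounds than are shown below. What is called first, only, known or untested is meant among the compounds shown, and "the series" means these compounds.

In an in vivo ADME assay on the whole organism (plasma) for pharmacokinetics, with Canis familiaris (Canis lupus familiaris) as the target, at a dose of 1 mg/kg by the oral route (on this read-out higher numbers stand for higher exposure at the dose given and lower numbers for lower exposure), compound 1 (`CCCC[C@H]1CN(c2cccc(C)c2C)C(=O)CN1Cc1cncn1Cc1ccc(C#N)cc1`) gives 140 nM as the lowest of three numbers, well beyond the scatter from the other two. Compound 2 (`N#Cc1ccc(Cn2cncc2CN2CCN(c3cccc(Cl)c3)CC2=O)cc1`) at 3140 nM and compound 3 (`N#Cc1ccc(Cn2cncc2CN2CCN(c3cccc(Cl)c3)C(=O)C2=O)cc1`) at 3110 nM carry no butyl, but they also differ from compound 4 (`Cc1cccc(N2CCN(Cc3cncn3Cc3ccc(C#N)cc3)CC2=O)c1C`) elsewhere. Compound 4 is still unmeasured and differs from compound 1 in one place: hydrogen in place of butyl on a saturated ring carbon. Within the data shown here, no measured pair shows this change alone, so the evidence is indirect. A rise beyond the scatter is expected, and the estimated step runs an 11-fold higher number from compound 1 to compound 4 (1.03 log units; beyond the scatter) upward. For compound 4 the estimate is 1500 nM with an expected range from 400 nM to 4500 nM in this measurement.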

Compound 4, maximal plasma concentration in the Canis familiaris assay: 1060 nM
Compound 4: the middle estimate sits 1.4-fold (0.15 log units) above what was measured; measured number inside the range.
By their numbers in the Canis familiaris assay, from the lowest: compound 1; then compound 4; then compounds 3 and 2 (each within the scatter of the next).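

Among these compounds, in the Canis familiaris assay, hydrogen in place of butyl on a saturated ring carbon gives a 7.6-fold higher number from compound 1 to compound 4 (0.88 log units; beyond the scatter), the first direct reading of this position. In a physicochemical assay for lipophilicity (a lower number here means a more polar compound, a higher number a more lipophilic compound), compound 1 gives > 3.7, which is a limit of the assay and not a number. In the physicochemical assay compound 4 gives 2 as a measured number. The same change leaves a more polar compound, a possible link to the higher exposure: the measured partition coefficient of compound 1, > 3.7, and of compound 4, 2, a number at least 1.70 log units lower (beyond the scatter)

A single pair cannot separate the effect of polarity from the loss of the butyl itself. On these data alone, whether a shorter chain such as methyl, or an amine on this carbon, would keep the rise stays open.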